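The compounds below may be only part of what the source reports. "The series", "measured", "known", "first", "only" and "open" are said of these compounds alone.

Measured in an ADME assay on microsomes from liver (Homo sapiens) for pharmacokinetics; on this read-out lower numbers stand for slow clearance and higher numbers for fast clearance:
- compound 1 `Cc1c(Nc2nc(N)c3c(C#N)c(N4CCC[C@H]4C)n(C)c3n2)cnn1C`: 41.7 mL/min/kg
- compound 2 `Cc1c(Nc2nc(N)c3c(C#N)c(N4CCC[C@H]4C)n(C)c3n2)cnn1CC1(O)COC1`: 35 mL/min/kg
- compound 3 `C[C@@H]1CCCN1c1c(C#N)c2c(N)nc(Nc3cn(C)nc3Cl)nc2n1C`: 183 mL/min/kg

Compound 3, at 183 mL/min/kg, has the highest number of the three. Compound 4 `Cc1c(Nc2nc(N)c3c(C#N)c(N4CCC[C@H]4C)n(C)c3n2)cnn1C1COC1` is not yet measured. It carries 5-methyl-1-(oxetan-3-yl)-1H-pyrazol-4-yl in place of 3-chloro-1-methyl-1H-pyrazol-4-yl on a nitrogen on an aromatic ring.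

Among the compounds with values here, two measured steps bear on this change. The closer one is a 4.4-fold higher number from compound 1 to compound 3 (0.64 log units; beyond the scatter), where 3-chloro-1-methyl-1H-pyrazol-4-yl replaced 1,5-dimethyl-1H-pyrazol-4-yl at the same place. Compound 4 gives up that chlorinated group, so a move back towards the level of compound 1 is expected. The other is a 1.2-fold lower number from compound 1 to compound 2 (0.08 log units; within the scatter), where 3-hydroxyoxetan-3-yl replaced hydrogen on a saturated chain carbon bound to an aromatic nitrogen. Within the data shown here, that step suggests an oxetane-bearing substituent need not move the number much, although no measured compound carries the exact group found in compound 4.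

A drop of about the same size as the first step is therefore expected, beyond the scatter. The expected change is a 4.6-fold lower number from compound 3 to compound 4 (0.66 log units; beyond the scatter). For compound 4 the estimated clearance is 40 mL/min/kg, with an expected range of 20 mL/min/kg to 85 mL/min/kg.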

Compound 4, clearance: 14.3 mL/min/kg
The estimate for compound 4 lay 2.8-fold (0.45 log units) above the measured number; measured number outside the range, below it.
By their numbers in this assay, from the lowest: compound 4; then compounds 2 and 1 (each within the scatter of the next); then compound 3.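

In this assay, the exchange of 3-chloro-1-methyl-1H-pyrazol-4-yl for 5-methyl-1-(oxetan-3-yl)-1H-pyrazol-4-yl gives a 13-fold lower number from compound 3 to compound 4 (1.11 log units; beyond the scatter), so removing the chlorinated group does more here than reverse a 4.4-fold higher number from compound 1 to compound 3 (0.64 log units; beyond the scatter): the number ends beyond the scatter of the level of compound 1. The group on the aromatic nitrogen therefore matters more than a 1.2-fold lower number from compound 1 to compound 2 (0.08 log units; within the scatter) suggested, since oxetan-3-yl in place of methyl gives a 2.9-fold lower number from compound 1 to compound 4 (0.46 log units; beyond the scatter), and oxetan-3-yl in place of (3-hydroxyoxetan-3-yl)methyl gives a 2.4-fold lower number from compound 2 to compound 4 (0.39 log units; beyond the scatter); an oxetane ring alone does not set the number, as compound 2 and compound 4 both carry one and still differ beyond the scatter. Nothing available explains why compound 4 has the lowest number of the set.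

The step from compound 3 changes two features of the pyrazole at once, so the share belonging to the exchange of chlorine for methyl and the share belonging to oxetan-3-yl on the aromatic nitrogen cannot be separated. Also open, from the compounds shown here alone, is whether other groups on that nitrogen, such as a piperidin-4-yl amine or a chain ending in a carboxylic acid, would hold the number at this level.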